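The compounds below may be only part of what the source reports. "The series", "measured", "known", "first", "only" and "open" are said of these compounds alone.

Compound 1 `Clc1ncnc2c1ncn2CC1COc2ccccc2S1`: 10600 nM
Compound 2 `Brc1ncnc2c1ncn2CC1COc2ccccc2S1`: 6180 nM

Among the measured compounds shown here, in a functional assay on MCF7 cells (Homo sapiens) for antiproliferative activity, read by colorimetric assay and sulforhodamine B assay, with a stated time of 3 days (on this read-out lower numbers stand for stronger inhibition and higher numbers for weaker inhibition), compound 1 gives 10600 nM, and the only other measured compound lies close to it: a 1.7-fold lower number from compound 1 to compound 2 (0.23 log units; within the scatter). The two cannot be told apart on these numbers. The next compound, compound 3 `Clc1nc(Cl)c2ncn(CC3COc4ccccc4S3)c2n1`, has not yet been measured. Its difference from compound 1 is chloro in place of hydrogen on an aromatic carbon, so a chloro replaces hydrogen on an aromatic carbon between two ring nitrogen atoms. For the measured compounds named here, the one measured step, a 1.7-fold lower number from compound 1 to compound 2 (0.23 log units; within the scatter), exchanges one halogen for another and adds no new group, so it bears only loosely on this change. It offers no sign of a large effect from a halogen on this core. A modest move towards a lower number is expected, though it may not clear the scatter. The estimated step is a 1.9-fold lower number from compound 1 to compound 3 (0.28 log units; within the scatter). For compound 3 the expected value is 5500 nM, with an estimated range from 2000 nM to 15000 nM.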

Compound 3, half-maximal inhibitory concentration: 8970 nM
Estimate against measurement, compound 3: 1.6-fold (0.21 log units) below, and the stated range covers the measured number.
By their numbers in this assay, from the lowest: compounds 2, 3 and 1 (each within the scatter of the next).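

In this assay, a chloro on the aromatic carbon between two ring nitrogen atoms gives a 1.2-fold lower number from compound 1 to compound 3 (0.07 log units; within the scatter), so compound 3 cannot be told apart from compound 1. The earlier step only exchanged one halogen for another at a different carbon, whereas this one adds a group at a new position and shows that a single chloro here brings no change these numbers can resolve. Nothing available bears on why this is so.

The compounds shown leave open whether this position would stay as unresponsive with a larger or different group, such as an amine, a methoxy group or a longer chain. They also leave open whether an amine in place of the chloro already present in compound 1 would move the number beyond the scatter.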